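Amide chain substitution in the indoline-quinazoline series

The source may report more compounds than this note shows. Statements on the series, on what has been measured and on what is new or still open speak of the compounds shown alone.

Measured compounds:
compound 1 `C/C=C/C(=O)Nc1cc2c(N3CCc4ccccc43)ncnc2cc1OC`: 4030 nM
compound 2 `C/C=C/C(=O)Nc1cc2c(N3CCc4ccccc43)ncnc2cc1O[C@@H]1CCOC1`: 4900 nM
compound 3 `CCC/C=C/C(=O)Nc1cc2c(N3CCCc4ccccc43)ncnc2cc1OC`: 1210 nM

In a functional assay on MCF7 cells (Homo sapiens) for antiproliferative activity, read by MTT assay, with a stated time of 72 h (on this read-out higher numbers stand for weaker inhibition and lower numbers for stronger inhibition), compound 1 gives 4030 nM and stands second highest of the three numbers. Its nearest neighbour is compound 2, reached by a 1.2-fold higher number from compound 1 to compound 2 (0.08 log units; within the scatter). For the measured compounds named here, compound 3 differs from compound 1 in two places at once; in this assay compound 3 gives 1210 nM, a lower number that lies beyond the scatter, and no single step links compound 3 to compound 1.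

Compound 4 `COc1cc2ncnc(N3CCc4ccccc43)c2cc1NC(=O)/C=C/CN1CCCCC1` is not yet measured. Relative to compound 1 the change is piperidin-1-yl in place of hydrogen on a saturated chain carbon bound to a double-bonded chain carbon. Going by the values given here, none of the measured steps touches the amide chain: the only single step, a 1.2-fold higher number from compound 1 to compound 2 (0.08 log units; within the scatter), alters the ether oxygen on the aromatic ring and stays within the scatter, and the pair of compound 1 and compound 3 mixes a chain extension with a ring-size change. The series therefore gives no direct guide for this position, and the expectation is held open around the value of compound 1, with a wide range.

The estimate for compound 4 in this assay is 3000 nM, ranging from 800 nM to 12000 nM. This expected value corresponds to a 1.3-fold lower number from compound 1 to compound 4 (0.13 log units; within the scatter).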

Compound 4, half-maximal inhibitory concentration: 1680 nM
Compound 4: middle estimate off by 1.8-fold (0.25 log units), on the high side; the measured number falls inside the stated range.
By their numbers in this assay, from the lowest: compounds 3 and 4 (each within the scatter of the next); then compounds 1 and 2 (each within the scatter of the next).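

In this assay, for the compounds shown here, the new step is a 2.4-fold lower number from compound 1 to compound 4 (0.38 log units; beyond the scatter), and it is the first single change to lie beyond the scatter, since the only earlier one, on the ether oxygen, stayed within it. The saturated chain carbon bound to a double-bonded chain carbon therefore accepts piperidin-1-yl, with its 6 heavy atoms and one six-membered non-aromatic ring, without any loss on this read-out, and the number moves modestly lower rather than higher. This single pair shows that the position can alter the number, but no measurement at hand accounts for the size or direction of the step.

The compounds shown leave open whether the piperidine ring itself matters at this place, or whether an open-chain amine such as dimethylamino, or another ring such as morpholin-4-yl or pyrrolidin-1-yl, would give a step of similar size. Also open, going by these compounds, is whether piperidin-1-yl on this chain gives a comparable step when oxolan-3-yl replaces methyl on the ether oxygen, as it does in compound 2.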